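Swapping the Amide Substituent of Compound 3

A few compounds are considered here, and "the series" means these few. Any claim that something is new, unique, unknown or untested is made for them only; others in the source may bear on it.

Three compounds sharing one core were measured in a functional assay (QGY7701 cells, Homo sapiens) for inhibition, read by MTT assay, with a stated time of 48 h; a lower number here means a stronger inhibitor, a higher number a weaker inhibitor. Compound 1 `O=C(/C=C/c1coc2cc(O)ccc2c1=O)NCc1ccc(F)cc1` reaches only the limit of the assay, > 100000 nM. Compound 2 `Cc1ccc(CNC(=O)/C=C/c2coc3cc(O)ccc3c2=O)cc1` gives 24900 nM, a step of an at least 4.0-fold lower number from compound 1 to compound 2 (0.60 log units; beyond the scatter). Compound 3 `COc1ccc2c(=O)c(/C=C/C(=O)NCc3ccc(F)cc3)coc2c1` gives 7960 nM, which is an at least 12-fold lower number from compound 1 to compound 3 (1.09 log units; beyond the scatter); among the two numbers shown it stands lowest, with compound 2 nearest. Both steps begin at a limit (the limit of > 100000 nM in this assay, at which 1 of the 3 values shown sits).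

Compound 4 `COc1ccc2c(=O)c(/C=C/C(=O)Nc3cccc(C)c3)coc2c1` differs from compound 3 by 3-methylphenyl in place of 4-fluorobenzyl on an amide-type nitrogen. Going by the values given here, no measured step alters the amide substituent in this way; the nearest is an at least 4.0-fold lower number from compound 1 to compound 2 (0.60 log units; beyond the scatter), which changes a group on the same ring while keeping the benzyl link, and it started from a limit rather than a number. With the methylated core of compound 3 kept intact, the change is expected to move this assay only modestly, and its direction is uncertain. Compound 4 is therefore expected to give about 9000 nM, between 2500 nM and 35000 nM, a step of a 1.1-fold higher number from compound 3 to compound 4 (0.05 log units; within the scatter).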

Compound 4, half-maximal inhibitory concentration: > 100000 nM
Compound 4 ended at the assay's limit (the forecaster's own chance of this, stated with the estimate: 5%); middle value at least 11-fold (1.04 log units) from the limit.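

The amide substituent proved to be a sensitive position on the core of compound 3: in this assay, the change to 3-methylphenyl gave an at least 12-fold higher number from compound 3 to compound 4 (1.09 log units; beyond the scatter). The earlier steps shown here altered only a group on the aromatic ring or the oxygen of the core and kept the benzyl link, whereas this step shows that activity can be lost through the amide-type nitrogen alone, even with the methylated core intact. Compound 4 stands at a limit of the assay and not at a number, so the full size of this step stays unknown: the limit of > 100000 nM in this assay, at which 2 of the 4 values shown sit.

The compounds shown do not separate the loss of the benzyl link from the exchange of the ring substituent, as both change together in this step. Also open, on these data alone, is how plain phenyl, plain benzyl or a longer chain would read on this nitrogen.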